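Amide aryl variation on a shared core

This account rests on a few compounds, and the source may have more. Where it says the series, first, only, none or still open, it means among the compounds named here.

Measured compounds:
compound 1 `Cc1ccc(C(=O)Nc2cccc(-c3oc4cc(-c5ccc(F)cc5)ccc4c(=O)c3O)c2)cc1` — 2320 nM
compound 2 `COc1cccc(C(=O)Nc2cccc(-c3oc4cc(-c5ccc(F)cc5)ccc4c(=O)c3O)c2)c1` — 9950 nM
compound 3 `Cc1cccc(C(=O)Nc2cccc(-c3oc4cc(-c5ccc(F)cc5)ccc4c(=O)c3O)c2)c1` — 13500 nM

In a functional assay on HepG2 cells (Homo sapiens) for antiproliferative activity, read by CCK-8 assay, with a stated time of 72 h (a higher number here means a weaker inhibitor, a lower number a stronger inhibitor), compound 3 gives the highest number of the three, but its gap to compound 2, a 1.4-fold higher number from compound 2 to compound 3 (0.13 log units; within the scatter), lies within the scatter, so these two cannot be ordered. The gap to compound 1, a 5.8-fold higher number from compound 1 to compound 3 (0.76 log units; beyond the scatter), lies beyond it, as does a 4.3-fold higher number from compound 1 to compound 2 (0.63 log units; beyond the scatter).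

Compound 4 `O=C(Nc1cccc(-c2oc3cc(-c4ccc(F)cc4)ccc3c(=O)c2O)c1)c1cccc(F)c1` differs from compound 3 by fluoro in place of methyl on an aromatic carbon. Going by the values given here, the only measured step at that same position is a 1.4-fold higher number from compound 2 to compound 3 (0.13 log units; within the scatter), a small change that stays within the scatter. Among the compounds with values here, no measured step swaps methyl for fluoro, so the information bearing on this change is thin; the one comparison available suggests that a small group exchange at this position moves the number little.

Compound 4 is therefore expected to land near compound 3, around 12000 nM, with a range of 5000 nM to 30000 nM. The expected step, a 1.1-fold lower number from compound 3 to compound 4 (0.05 log units; within the scatter), is estimated to stay within the scatter.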

Compound 4, half-maximal inhibitory concentration: 15500 nM
The estimate for compound 4 lay 1.3-fold (0.11 log units) below the measured number; measured number inside the range.
By their numbers in this assay, from the lowest: compound 1; then compounds 2, 3 and 4 (each within the scatter of the next).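

Fluoro in place of methyl on the amide aryl ring leaves the number unresolved in this assay (a 1.1-fold higher number from compound 3 to compound 4 (0.06 log units; within the scatter)), and fluoro in place of methoxy does likewise (a 1.6-fold higher number from compound 2 to compound 4 (0.19 log units; within the scatter)). Methyl, methoxy and fluoro therefore cannot be separated here on this evidence, whereas the earlier compounds offered only the methoxy and methyl comparison. The 3-fluorophenyl amide also stands apart from the 4-methylphenyl amide (a 6.7-fold higher number from compound 1 to compound 4 (0.82 log units; beyond the scatter)), so compounds 2, 3 and 4 all lie beyond the scatter from compound 1, and nothing at hand gives a reason for these steps.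

Whether the lower number of compound 1 belongs to 4-methyl substitution alone stays open without a 4-fluorophenyl or 4-methoxyphenyl partner among the compounds shown. Going by these compounds, how an amine or a carboxylic acid on this ring would read also remains open.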